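A few compounds are considered here, and "the series" means these few. Any claim that something is new, unique, unknown or untested is made for them only; others in the source may bear on it.

Compound 1 `O=C(CCCCCCc1ccccc1)c1ncc(-c2ccc([N+](=O)[O-])cc2)o1` is one of three members of this series tested in an assay (Rattus norvegicus) for inhibition of Fatty-acid amide hydrolase 1 (Homo sapiens) (on this read-out lower numbers stand for stronger inhibition and higher numbers for weaker inhibition), where compound 1 gives 50 nM. That is the highest of the three numbers. Compound 2 `O=C(CCCCCCc1ccccc1)c1ncc(-c2cc(C(F)(F)F)ccn2)o1` gives 3.5 nM, and compound 3 `COC(=O)c1ccc(-c2cnc(C(=O)CCCCCCc3ccccc3)o2)nc1` gives 3.5 nM; both stand well beyond the scatter away from compound 1, and between themselves they lie within it. The step now followed leads to compound 4 `O=C(CCCCCCc1ccccc1)c1ncc(-c2nnn[nH]2)o1`, which differs from compound 1 in one place: 1H-tetrazol-5-yl in place of 4-nitrophenyl on an aromatic carbon. Among the compounds with values here, no measured pair in the set shares this change, so there is nothing to anchor its size. Compound 4 is expected to show a modest shift toward a weaker number, a 3.0-fold higher number from compound 1 to compound 4 (0.48 log units; beyond the scatter), with wide uncertainty. Compound 4 is thus estimated at 150 nM, within 25 nM to 1500 nM.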

Compound 4, inhibition constant: 63 nM
For compound 4 the middle estimate is 2.4-fold (0.38 log units) above the measured one; the measured number falls inside the stated range.
By their numbers in this assay, from the lowest: compounds 2 and 3 (each within the scatter of the next); then compounds 1 and 4 (each within the scatter of the next).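

Replacing 4-nitrophenyl with 1H-tetrazol-5-yl on the aromatic carbon next to the ring oxygen gives a 1.3-fold higher number from compound 1 to compound 4 (0.10 log units; within the scatter) in this assay. This position therefore accepts a five-membered aromatic ring with 4 hetero atoms in place of a six-membered carbon ring with no change beyond the scatter, even though the entering group has fewer heavy atoms and adds a hydrogen-bond donor. No measured property of either group accounts for this. On these data alone, whether a carboxylic acid or an amine at the same place would read like compound 1 or compound 4 remains open.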